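Aryl swap on a triazole amide pair at the limit

The source may report more compounds than this note shows. Statements on the series, on what has been measured and on what is new or still open speak of the compounds shown alone.

Compound 1 `Cc1ccc(-n2cc(CNC(=O)c3cccc4c3cnn4C(C)C)nn2)cc1C`: > 40000 nM
Compound 2 `CC(C)n1ncc2c(C(=O)NCc3cn(-c4ccc(I)cc4)nn3)cccc21`: > 40000 nM

In a functional assay on HepG2 cells (Homo sapiens) for inhibition, read by MTT assay, with a stated time of 72 h (a lower number here means a stronger inhibitor, a higher number a weaker inhibitor), compound 1 sits at a limit of the assay, > 40000 nM. In this assay compound 2 also sits at a limit, > 40000 nM. Going by the values given here, both values rest at the limit of > 40000 nM in this assay, at which 2 of the 2 values shown sit, and the one measured step, a step that the two limits leave unreadable from compound 1 to compound 2, cannot be sized. Compound 3 `CC(C)n1ncc2c(C(=O)NCc3cn(-c4cccc(F)c4)nn3)cccc21` differs from compound 2 by 3-fluorophenyl in place of 4-iodophenyl on an aromatic nitrogen. Among the compounds with values here, the only step that bears on this change is the unreadable one, which gives no direction to expect beyond the scatter. Compound 3 is therefore expected to remain at the limit, estimated at 40000 nM (range 20000 nM to 150000 nM), an expected step of a number no higher from compound 2 to compound 3 (the limit leaves the size open) of essentially none.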

Compound 3, half-maximal inhibitory concentration: > 40000 nM
Compound 3 gave a limit, no number (the forecaster's own chance of this, stated with the estimate: 85%); the middle value lies on the limit itself.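

No new step can be read among compound 1, compound 2 and compound 3, each value being a limit and not a number: the limit of > 40000 nM in this assay, at which 3 of the 3 values shown sit. The compounds shown leave open how far any of these aryl groups on the aromatic nitrogen changes inhibition.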